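This account rests on a few compounds, and the source may have more. Where it says the series, first, only, none or still open, it means among the compounds named here.

Working notes on the series.

In a functional assay on MCF7 cells (Homo sapiens) for inhibition, read by MTT assay, with a stated time of 72 h (a higher number here means a weaker inhibitor of growth, a lower number a stronger inhibitor of growth), compound 1 `O=S(=O)(NCCCNCc1ccc(Cl)c(C(F)(F)F)c1)c1cc(C(F)(F)F)cc(C(F)(F)F)c1` gives 3500 nM, and compound 2 `CN(CCCNS(=O)(=O)c1cc(C(F)(F)F)cc(C(F)(F)F)c1)Cc1ccccc1` gives 16000 nM. On these two numbers compound 2 stands at the highest, that is the weaker end, and the gap to compound 1 lies beyond the scatter. Compound 3 `O=S(=O)(NCCCNCc1ccccc1)c1cc(C(F)(F)F)cc(C(F)(F)F)c1` is not yet measured in this assay. It differs from compound 2 by hydrogen in place of methyl on an amine nitrogen, which leaves compound 3 with a secondary amine in the chain, as in compound 1. Going by the values given here, no measured pair shows this change on its own, so the size of the step is open. Given that compound 1, which also carries a secondary amine, gives 3500 nM, compound 3 is expected to move somewhat toward the stronger side, with an estimated step of a 2.0-fold lower number from compound 2 to compound 3 (0.30 log units; within the scatter). In this assay compound 3 is estimated at 8000 nM, within a range of 3000 nM to 25000 nM.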

Compound 3, concentration for 50% growth inhibition: 3000 nM
Compound 3: the middle estimate sits 2.7-fold (0.43 log units) above what was measured, within the range that was stated.
By their numbers in this assay, from the lowest: compounds 3 and 1 (each within the scatter of the next); then compound 2.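

In this assay, hydrogen in place of methyl on an amine nitrogen now has a measured size: a 5.3-fold lower number from compound 2 to compound 3 (0.73 log units; beyond the scatter) is a step beyond the scatter, so in this pair the methyl on the nitrogen goes with the weaker number. Phenyl in place of 4-chloro-3-(trifluoromethyl)phenyl on a saturated chain carbon bound to an amine nitrogen gives a 1.2-fold lower number from compound 1 to compound 3 (0.07 log units; within the scatter) and stays within the scatter, so with the secondary amine kept, this change shows no readable effect. No measurement at hand bears on the reason for either step.

On these data alone, whether the methyl step carries over to the 4-chloro-3-(trifluoromethyl)phenyl compounds rests on this single pair and remains open. Also open, as far as these compounds go, is how an ethyl group on the same nitrogen, or a longer chain in the shared core, would read in this assay here.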